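Difluoromethyl in Place of Trifluoromethyl on Two Cores

The source may report more compounds than this note shows. Statements on the series, on what has been measured and on what is new or still open speak of the compounds shown alone.

Measured compounds:
Compound 1, `C[C@@H]1CN(c2c(C#N)c(C(F)(F)F)nn2-c2ccc(S(C)(=O)=O)cn2)[C@H](C)CO1`: > 200 ug/mL
Compound 2, `C[C@@H]1CN(c2c(C#N)c(C(F)F)nn2-c2ccc(S(C)(=O)=O)cn2)[C@H](C)CO1`: > 200 ug/mL
Compound 3, `CC(C)(C)CNc1c(C#N)c(C(F)(F)F)nn1-c1ccc(S(C)(=O)=O)cc1`: "not determined" (no result reported)

In a physicochemical assay for solubility (a higher number here means a more soluble compound, a lower number a less soluble compound), compound 1 gives > 200 ug/mL, which is a limit of the assay and not a number. Compound 2 likewise gives > 200 ug/mL in this assay, again a limit. The change between them is hydrogen in place of fluoro on a saturated chain carbon bound to an aromatic carbon and two fluorine atoms, and the resulting step, a step that the two limits leave unreadable from compound 1 to compound 2, cannot be sized because both values sit at the limit of > 200 ug/mL in this assay, at which 2 of the 3 values shown sit. Compound 3, `CC(C)(C)CNc1c(C#N)c(C(F)(F)F)nn1-c1ccc(S(C)(=O)=O)cc1`, carries a different core; the difference between the two cores is not broken down here, and for compound 3 this assay gives "not determined" (no result reported). Compound 4, `CC(C)(C)CNc1c(C#N)c(C(F)F)nn1-c1ccc(S(C)(=O)=O)cc1`, arises from compound 3 by hydrogen in place of fluoro on a saturated chain carbon bound to an aromatic carbon and two fluorine atoms, the same change as from compound 1 to compound 2. With the earlier step unreadable and compound 3 unmeasured, the expectation for compound 4 rests on little; the estimate for compound 4 in this assay is 110 ug/mL, between 25 ug/mL and 250 ug/mL.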

Compound 4, solubility: > 200 ug/mL
Compound 4: only a limit was reported; the forecaster's own chance of this, stated with the estimate: 35%; at least 1.8-fold (0.25 log units) between middle value and limit.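

In this assay compound 4 gives > 200 ug/mL, which is a limit of the assay and not a number. No step can be read from compound 3 to compound 4. The compounds shown leave open how far trifluoromethyl to difluoromethyl changes solubility on either core.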